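A few compounds are considered here, and "the series" means these few. Any claim that something is new, unique, unknown or untested is made for them only; others in the source may bear on it.

Measured in a functional assay on MCF7 cells (Homo sapiens) for antiproliferative activity, read by MTT assay, with a stated time of 24 h; on this read-out lower numbers stand for stronger inhibition and higher numbers for weaker inhibition:
- Compound 1 `CCn1c(C(=O)NCC(=O)OC)ccc1C(CC)(CC)c1ccc(OCS(=O)(=O)c2ccccc2)c(C)c1`: > 50000 nM (a limit)
- Compound 2 `CCn1c(C(=O)N[C@@H](CC(=O)OC)C(=O)OC)ccc1C(CC)(CC)c1ccc(OCS(=O)(=O)c2ccccc2)c(C)c1`: > 50000 nM (a limit)
- Compound 3 `CCn1c(C(=O)N[C@@H](CO)CCO)ccc1C(CC)(CC)c1ccc(OCS(=O)(=O)c2ccccc2)c(C)c1`: 27400 nM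

Of these three, only compound 3 has an actual number, 27400 nM. Compound 1 and compound 2 report only (the limit of > 50000 nM in this assay, at which 2 of the 3 values shown sit). The measured steps that bear on compound 3 are an at least 1.8-fold lower number from compound 1 to compound 3 (0.26 log units; that floor lies within the scatter) and an at least 1.8-fold lower number from compound 2 to compound 3 (0.26 log units; that floor lies within the scatter), so neither sets compound 3 apart beyond the scatter. The remaining step, a step that the two limits leave unreadable from compound 1 to compound 2, adds nothing.

Compound 4 `CCn1c(C(=O)N[C@@H](C)C(=O)O)ccc1C(CC)(CC)c1ccc(OCS(=O)(=O)c2ccccc2)c(C)c1` changes the same place, with 1-carboxyethyl in place of 3-hydroxy-1-(hydroxymethyl)propyl on an amide-type nitrogen. For the measured compounds named here, no measured compound carries this group, so the guide is loose: each group tried there so far has left compound 1, compound 2 or compound 3 weak, with an at least 1.8-fold lower number from compound 2 to compound 3 (0.26 log units; that floor lies within the scatter) as the only readable hint of a difference. The expected move is a 1.3-fold higher number from compound 3 to compound 4 (0.11 log units; within the scatter), which would stay within the scatter. The estimate for compound 4 is 35000 nM, with an expected range of 12000 nM to 90000 nM.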

Compound 4, half-maximal inhibitory concentration: 35500 nM
Estimate against measurement, compound 4: 1.0-fold (0.01 log units) below; the range from low to high includes it.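

This position now has a second actual number in this assay and the step between the two numbers (a 1.3-fold higher number from compound 3 to compound 4 (0.11 log units; within the scatter)) shows that 1-carboxyethyl and 3-hydroxy-1-(hydroxymethyl)propyl on the amide-type nitrogen cannot be told apart here. The steps from the two compounds held at a limit (an at least 1.4-fold lower number from compound 2 to compound 4 (0.14 log units; that floor lies within the scatter) and an at least 1.4-fold lower number from compound 1 to compound 4 (0.14 log units; that floor lies within the scatter)) give only floors, so they do not separate 1-carboxyethyl from 1,2-bis(methoxycarbonyl)ethyl or (methoxycarbonyl)methyl either. The step between compound 1 and compound 2 still cannot be read: the limit of > 50000 nM in this assay, at which 2 of the 4 values shown sit.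

The groups shown at this place are all chains carrying hydroxyl, ester or carboxylic acid groups, so the effect of an amine or a benzyl group there remains open. On these data alone, whether any group at this place can give a much lower number also stays unknown.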